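From 4-bromophenyl to 2,6-dimethoxyphenyl in a growth assay

The source may report more compounds than this note shows. Statements on the series, on what has been measured and on what is new or still open speak of the compounds shown alone.

Within the data shown here, in a functional assay on DU-145 cells (Homo sapiens) for inhibition, read by trypan blue exclusion, with a stated time of 96 h (a higher number here means a weaker inhibitor of growth, a lower number a stronger inhibitor of growth), compound 3 `O=C(/C(=C\c1ccc(Br)cc1)S(=O)(=O)c1ccc(Br)cc1)c1ccc(Br)cc1` gives 10000 nM, the second highest of the three numbers so far. Compound 1 `COc1ccc(/C=C(\C(=O)c2ccc(Br)cc2)S(=O)(=O)c2ccc(Br)cc2)cc1` gives 25000 nM, and compound 2 `O=C(/C(=C\c1csc([N+](=O)[O-])c1)S(=O)(=O)c1ccc(Br)cc1)c1ccc(Br)cc1` gives 1000 nM. Compound 4 `COc1cccc(OC)c1/C=C(\C(=O)c1ccc(Br)cc1)S(=O)(=O)c1ccc(Br)cc1` has 2,6-dimethoxyphenyl in place of 4-bromophenyl on a double-bonded chain carbon bound to a double-bonded chain carbon. Two measured steps change the group at this place. The closer one, with bromo in place of methoxy on an aromatic carbon, is a 2.5-fold lower number from compound 1 to compound 3 (0.40 log units; beyond the scatter). It suggests that methoxy groups may not help. The other, a 10-fold higher number from compound 2 to compound 3 (1.00 log units; beyond the scatter), shows that this place can move the number substantially, but it involves a different kind of group. Among the measured compounds shown here, no measured compound carries the 2,6-dimethoxyphenyl group, so the direction remains uncertain. The expected change is small, with no shift beyond the scatter: a 1.3-fold lower number from compound 3 to compound 4 (0.10 log units; within the scatter). For compound 4 the estimated value is 8000 nM, with an expected range of 1500 nM to 30000 nM.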

Compound 4, concentration for 50% growth inhibition: 10000 nM
For compound 4 the middle estimate is 1.3-fold (0.10 log units) below the measured one, within the range that was stated.
By their numbers in this assay, from the lowest: compound 2; then compounds 3 and 4 (each within the scatter of the next); then compound 1.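

In this assay, the step to 2,6-dimethoxyphenyl gives no change at the digits printed from compound 3 to compound 4 (within the scatter), so at this place a group with two methoxy groups and no bromine reads the same as 4-bromophenyl. Methoxy-bearing groups here also do not all share one number: the step between the two gives a 2.5-fold lower number from compound 1 to compound 4 (0.40 log units; beyond the scatter), while 5-nitrothiophen-3-yl remains clearly ahead of the new group, with a 10-fold higher number from compound 2 to compound 4 (1.00 log units; beyond the scatter). Nothing at hand accounts for these differences.

The compounds shown leave open whether the low number of compound 2 belongs to the nitro group or to the ring that carries it, as no compound here has one without the other. Also open, on these data alone, is how an amine or a carboxylic acid on the aromatic ring at this place would read.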